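Lengthening the Hydroxycarbamoyl Chain from Compound 3 to Compound 4

This account rests on a few compounds, and the source may have more. Where it says the series, first, only, none or still open, it means among the compounds named here.

Measured in a functional assay on HepG2 cells (Homo sapiens) for inhibition, read by MTT assay, with a stated time of 72 h; on this read-out higher numbers stand for weaker inhibition and lower numbers for stronger inhibition:
Compound 1, `Nc1ncnc2c1c(-c1cnc3[nH]ccc3c1)nn2CC(=O)NO`, gives only a limit, > 150000 nM.
Compound 2, `Nc1nc2cc(-c3nn(CCCC(=O)NO)c4ncnc(N)c34)ccc2o1`, gives only a limit, > 50000 nM.
Compound 3, `Nc1ncnc2c1c(-c1cnc3[nH]ccc3c1)nn2CCCCC(=O)NO`, gives 36700 nM.

Within the data shown here, compound 3 thus holds the only number among the three; the other two values are limits of this assay. Compound 4, `Nc1ncnc2c1c(-c1cnc3[nH]ccc3c1)nn2CCCCCCCCCC(=O)NO`, differs from compound 3 by 5-(hydroxycarbamoyl)pentyl in place of hydroxycarbamoyl on a saturated chain carbon, four bonds along the chain from an aromatic nitrogen. Among the measured compounds shown here, one measured step bears on this: an at least 4.0-fold lower number from compound 1 to compound 3 (0.61 log units; beyond the scatter), which also lengthened the chain. A further, larger lengthening is therefore expected to give a modest step to a lower number in this assay, a 3.7-fold lower number from compound 3 to compound 4 (0.56 log units; beyond the scatter). Compound 4 is estimated at 10000 nM, with a range from 3000 nM to 36000 nM.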

Compound 4, half-maximal inhibitory concentration: 11700 nM
The estimate for compound 4 lay 1.2-fold (0.07 log units) below the measured number; low and high end bracket the measured number.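

In this assay, among these compounds, this position now gives a step between two measured numbers for the first time: a 3.1-fold lower number from compound 3 to compound 4 (0.50 log units; beyond the scatter). The 5-(hydroxycarbamoyl)pentyl chain thus continues the direction seen on going from compound 1 to compound 3, a step whose size stayed open since it starts from a limit: the limit of > 150000 nM in this assay, at which 1 of the 4 values shown sits.

Open, as far as these compounds go, is whether a longer chain than that of compound 4 would lower the number further. Also open, from the compounds shown here alone, is whether a carboxylic acid or an amine at the chain end, in place of the hydroxycarbamoyl group, would keep this step.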